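From cyclobutyl to 3-hydroxycyclobutyl: compound 1 to compound 4

The compounds below may be only part of what the source reports. "The series", "measured", "known", "first", "only" and "open" are said of these compounds alone.

In an ADME assay on microsomes from liver (Homo sapiens) for metabolic stability, read by LC-MS, using NADPH, with a stated time of 10 min, tested at 10 uM (a higher number here means that the compound lasts longer, a lower number that the compound disappears faster), compound 1 `N#Cc1ccnc(Oc2nn(C3CCC3)c3ncnc(N)c23)c1` gives 2.35 h, the higher of the two true numbers available. The other number comes from compound 3 `Nc1ncnc2c1c(Oc1cc(Cl)ccn1)nn2C1CCC1`, which gives 0.333 h. Compound 2 `Nc1ncnc2c1c(Oc1cc(C(F)(F)F)ccn1)nn2C1CC1` is reported only as a limit of the assay, > 2.41 h, and not as a number.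

The next compound to consider is compound 4 `N#Cc1ccnc(Oc2nn([C@H]3C[C@@H](O)C3)c3ncnc(N)c23)c1`. It keeps the core of compound 1 and carries one change, hydroxy in place of hydrogen on a saturated ring carbon, which turns cyclobutyl into 3-hydroxycyclobutyl.

Going by the values given here, only one measured step changes a single place, and that is a 7.1-fold lower number from compound 1 to compound 3 (0.85 log units; beyond the scatter). This modest step, chloro in place of cyano, sits on an aromatic carbon and not on the saturated ring. Among the compounds with values here, no measured step touches the cyclobutyl ring, so the data give no direction for this change. The expected change is therefore none beyond the scatter, with an estimated step of a 1.1-fold higher number from compound 1 to compound 4 (0.03 log units; within the scatter). Within the data shown here, the one measured step does show that a single change can move this read-out well beyond the scatter, so the range is kept wide. For compound 4 the estimated half-life is 2.5 h, with an expected range from 0.9 h to 6 h.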

Compound 4, half-life: > 2.41 h
Compound 4: only a limit was reported; the forecaster's own chance of this, stated with the estimate: 45%; the middle value lies beyond the limit too.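

In this assay compound 4 gives > 2.41 h, which is a limit of the assay and not a number. The step reads an at least 1.0-fold higher number from compound 1 to compound 4 (0.01 log units; that floor lies within the scatter), so this first look at a change on the cyclobutyl ring shows that hydroxy in place of hydrogen on a saturated ring carbon does not shorten the half-life, unlike the change on the aromatic carbon in a 7.1-fold lower number from compound 1 to compound 3 (0.85 log units; beyond the scatter). Only this floor can be read, and it does not show a real rise, since the top of the measured range is reached at this position as well as in another compound of the series: the limit of > 2.41 h in this assay, at which 2 of the 4 values shown sit.

Going by these compounds, how far compound 4 lies beyond its limit stays open, so the size of any gain from 3-hydroxycyclobutyl remains unknown. Also open, on these data alone, is whether an amine or a methoxy group on the same ring carbon would leave the half-life just as intact, and whether the hydroxy would have the same effect with chloro in place of cyano, as in compound 3, which gives 0.333 h.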